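A few compounds are considered here, and "the series" means these few. Any claim that something is new, unique, unknown or untested is made for them only; others in the source may bear on it.

- Compound 1 (`CN(C)Cc1ccc2nc(NC(=O)N/N=C/c3cn(Cc4ccccc4Cl)c4ccccc34)sc2c1`): 1600 nM
- Compound 2 (`Cc1ccc(Cn2cc(/C=N/NC(=O)Nc3nc4ccc(CN5CCC(C)CC5)cc4s3)c3ccccc32)cc1`): 410 nM

In a functional assay on NCI-H460 cells (Homo sapiens) for cytotoxicity, read by MTT assay, with a stated time of 72 h (on this read-out lower numbers stand for stronger inhibition and higher numbers for weaker inhibition), compound 1 gives 1600 nM and holds the higher of the two numbers, a gap to compound 2 that lies beyond the usual scatter. Compound 3 (`CN(C)Cc1ccc2nc(NC(=O)N/N=C/c3cn(Cc4cccc(Cl)c4)c4ccccc34)sc2c1`) keeps the core of compound 1 and changes one group (3-chlorophenyl in place of 2-chlorophenyl on a saturated chain carbon bound to an aromatic nitrogen): 3-chlorophenyl in place of 2-chlorophenyl on a saturated chain carbon bound to an aromatic nitrogen. For the measured compounds named here, no measured pair shows what this swap does, so no step beyond the scatter is expected in this assay for now. The expected change is small (a 1.2-fold lower number from compound 1 to compound 3 (0.09 log units; within the scatter)) and could go either way. For compound 3 the estimated value is 1300 nM with an expected range of 550 nM to 3000 nM around it.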

Compound 3, half-maximal inhibitory concentration: 420 nM
Compound 3: middle estimate off by 3.1-fold (0.49 log units), on the high side; the measured number lies below the stated range.
By their numbers in this assay, from the lowest: compounds 2 and 3 (each within the scatter of the next); then compound 1.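

In this assay, replacing 2-chlorophenyl with 3-chlorophenyl gives a 3.8-fold lower number from compound 1 to compound 3 (0.58 log units; beyond the scatter). This first single-change pair shows that this place on a saturated chain carbon bound to an aromatic nitrogen responds to where the chlorine sits on the ring, even though both compounds contain the same atoms. No supporting data bear on why the number drops.

As far as these compounds go, whether the chlorine itself is needed stays open, and a plain phenyl or a 3-bromophenyl in this place would test that. One pair also cannot show whether the same swap would behave alike on a different core.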